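The source may hold more compounds than are shown below. What is called first, only, known or untested is meant among the compounds shown, and "the series" means these compounds.

Measured in a functional assay on HL-60 cells (Homo sapiens) for inhibition, read by MTT assay, with a stated time of 72 h; a higher number here means a weaker inhibitor, a lower number a stronger inhibitor:
- Compound 1 `Cc1ccc(C)c(N2CCN(C(=O)c3oc(C)nc3-c3ccc(F)cc3)CC2)c1`: 358 nM
- Compound 2 `Cc1ccc(C)c(N2CCN(C(=O)c3oc(C)nc3-c3ccccc3)CC2)c1`: 31.3 nM
- Compound 3 `Cc1nc(-c2ccccc2Cl)c(C(=O)N2CCN(c3cccc(Cl)c3)CC2)o1`: 132 nM

In this assay, compound 3, at 132 nM, holds the middle place of the three numbers. It lies below compound 1 and above compound 2, and its gap to each is beyond the usual scatter.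

The next compound, compound 4 `Cc1ccc(C)c(N2CCN(C(=O)c3oc(C)nc3-c3ccccc3Cl)CC2)c1`, differs from compound 3 in one place, with 2,5-dimethylphenyl in place of 3-chlorophenyl on an amine nitrogen in a ring.

For the measured compounds named here, only one measured step exists, an 11-fold lower number from compound 1 to compound 2 (1.06 log units; beyond the scatter), and it is large. It comes from hydrogen in place of fluoro on an aromatic carbon, not from a change on the amine nitrogen, so it does not measure the present exchange. Going by the values given here, compound 1 and compound 2 both carry the 2,5-dimethylphenyl, but no measured pair isolates its effect against 3-chlorophenyl. The data therefore give no direction, and no step beyond the scatter is expected in this assay. Any such expectation stays loose because an 11-fold lower number from compound 1 to compound 2 (1.06 log units; beyond the scatter) shows how far a single change can move the number in these compounds.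

The estimated step is a 1.1-fold lower number from compound 3 to compound 4 (0.04 log units; within the scatter). For compound 4 the expected value is 120 nM, with an estimated range of 35 nM to 420 nM.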

Compound 4, half-maximal inhibitory concentration: > 1000 nM
Compound 4: no number, only a limit; the forecaster's own chance of this, stated with the estimate: 3%; middle value at least 8.3-fold (0.92 log units) from the limit.
By their numbers in this assay, from the lowest: compound 2; then compound 3; then compound 1. At a limit, above all of these: compound 4.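

Compound 4 gives only a limit in this assay, not a number: the limit of > 1000 nM in this assay, at which 1 of the 4 values shown sits.

For the compounds shown here, the group on the amine nitrogen, which no earlier pair isolated, can clearly move the number: with the 2-chlorophenyl kept, 2,5-dimethylphenyl in place of 3-chlorophenyl gives an at least 7.5-fold higher number from compound 3 to compound 4 (0.87 log units; beyond the scatter). The 2-chlorophenyl does not rule out a measurable number on its own, since compound 3, which carries it, gives 132 nM, yet with 2,5-dimethylphenyl on the nitrogen the same group gives an at least 31-fold higher number from compound 2 to compound 4 (1.50 log units; beyond the scatter) and, against the 4-fluorophenyl, an at least 2.7-fold higher number from compound 1 to compound 4 (0.44 log units; beyond the scatter). Among the compounds with 2,5-dimethylphenyl, then, both halogen-bearing aromatic groups stand above the unsubstituted phenyl of compound 2, and the 2-chlorophenyl stands highest.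

The compounds shown leave open how 3-chlorophenyl on the nitrogen behaves with the unsubstituted phenyl or the 4-fluorophenyl, so it remains unclear whether the rise belongs to the nitrogen group alone or to its pairing with 2-chlorophenyl. They also leave open how a methoxy group or an amine on the aromatic ring of the core would fare.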